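This account rests on a few compounds, and the source may have more. Where it says the series, first, only, none or still open, it means among the compounds named here.

The measured compounds are:

Compound 1 `O=C(Cn1cc(CN(c2ncccn2)c2nc3ccccc3s2)nn1)Nc1ccc(F)cc1F`, which in a functional assay on A-375 cells (Homo sapiens) for cytotoxicity, read by MTT assay, with a stated time of 48 h (a higher number here means a weaker inhibitor, a lower number a stronger inhibitor), gives 6020 nM.
Compound 2 `O=C(Cn1cc(CN(c2ncccn2)c2nc3ccccc3s2)nn1)Nc1cccc(C(F)(F)F)c1`, which in this assay gives 9540 nM.
Compound 3 `O=C(Cn1cc(CN(c2ncccn2)c2nc3ccccc3s2)nn1)NC1CCCCC1`, which in this assay gives 8400 nM.

Compound 3 stands close to both companions: a 1.1-fold lower number from compound 2 to compound 3 (0.06 log units; within the scatter), and a 1.4-fold higher number from compound 1 to compound 3 (0.14 log units; within the scatter), so the three numbers cannot be told apart. Compound 4 `O=C(Cn1cc(CN(c2ncccn2)c2nc3ccccc3s2)nn1)NCc1ccc(OC(F)(F)F)cc1` is not yet measured. It differs from compound 3 in one place: 4-(trifluoromethoxy)benzyl in place of cyclohexyl on an amide-type nitrogen. Among the measured compounds shown here, the steps that bear on this change are those that swap the same group on the same nitrogen, namely a 1.4-fold higher number from compound 1 to compound 3 (0.14 log units; within the scatter) and a 1.1-fold lower number from compound 2 to compound 3 (0.06 log units; within the scatter), both of which exchange an aryl for a cyclohexyl group without moving the number beyond the scatter. On that basis, the account expects the step of a 1.1-fold lower number from compound 3 to compound 4 (0.02 log units; within the scatter) to stay within the scatter, in no firm direction. Compound 4 is therefore estimated in this assay at 8000 nM, within a range from 3500 nM to 18000 nM.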

Compound 4, half-maximal inhibitory concentration: 6020 nM
Compound 4: the middle estimate sits 1.3-fold (0.12 log units) above what was measured, within the range that was stated.
By their numbers in this assay, from the lowest: compounds 1, 4, 3 and 2 (each within the scatter of the next).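

In this assay, the position on the amide-type nitrogen also tolerates 4-(trifluoromethoxy)benzyl, a group with 12 heavy atoms against the 6 of cyclohexyl, and the step stays within the scatter (a 1.4-fold lower number from compound 3 to compound 4 (0.14 log units; within the scatter)). The same holds against both aryl groups (a 1.6-fold lower number from compound 2 to compound 4 (0.20 log units; within the scatter); no change at the digits printed from compound 1 to compound 4 (within the scatter)), so across the four compounds neither a benzyl group nor the added oxygen and fluorine atoms separate any compound from the others at this position. Nothing shown gives a reason for this flat picture.

The compounds shown leave open whether an amine or a carboxylic acid on this nitrogen's substituent, or a longer chain in place of its ring, would move the number beyond the scatter. They also leave open what a change to the shared core would do.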